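Aryl for isopropyl on the ring nitrogen

A few compounds are considered here, and "the series" means these few. Any claim that something is new, unique, unknown or untested is made for them only; others in the source may bear on it.

Compound 1 `COc1cc(-c2nccn2C(C)C)cc(OC)c1OC` gives > 100000 nM in a functional assay on HeLa cells (Homo sapiens) for antiproliferative activity, read by MTT assay, with a stated time of 72 h (on this read-out lower numbers stand for stronger inhibition and higher numbers for weaker inhibition), which is a limit and not a number. This places compound 1 at the limit of > 100000 nM in this assay, at which 2 of the 3 values shown sit. Compound 2 `COc1cc(-c2nccn2S(=O)(=O)c2ccccc2)cc(OC)c1OC` gives > 100000 nM in this assay, also a limit. Compound 3 `COc1cc(-c2nccn2-c2ccc3[nH]ccc3c2)cc(OC)c1OC` is the only one of the three with a number, at 4400 nM.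

Compound 4 `COc1cc(-c2nccn2-c2cccc(C)c2)cc(OC)c1OC` has not yet been measured. It carries 3-methylphenyl in place of the isopropyl of compound 1 on an aromatic nitrogen, next to the ring atom that bears a large group (3-methylphenyl in place of isopropyl on an aromatic nitrogen).

Going by the values given here, no measured pair isolates this change, so the expectation is indirect. It rests on compound 3, at 4400 nM, which also has an aromatic ring bonded directly to that nitrogen. Compound 2 qualifies the comparison, since it carries a ring on the same nitrogen through a sulfonyl group and still gives > 100000 nM, a limit.

In this assay, a step towards stronger inhibition, beyond the usual scatter, is expected for the change an at least 6.6-fold lower number from compound 1 to compound 4 (0.82 log units; beyond the scatter). Compound 4 may still remain at the limit of the assay. The estimated value for compound 4 is 15000 nM, with an expected range of 2500 nM to 100000 nM.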

Compound 4, half-maximal inhibitory concentration: 1900 nM
Estimate against measurement, compound 4: 7.9-fold (0.90 log units) above; the whole stated range lies above it.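

In this assay compound 1 gives > 100000 nM, a limit of the assay. Going by these compounds alone, putting 3-methylphenyl in place of isopropyl on the aromatic nitrogen gives an at least 52-fold lower number from compound 1 to compound 4 (1.72 log units; beyond the scatter), the first step that can be read at this nitrogen, and it shows that a carbon-only aromatic ring bonded directly there is enough to bring a compound to a measured value, with no hydrogen-bond donors or acceptors in the entering group. The step has a bound rather than an exact size, and its true size may be larger, as its starting point is a limit and not a number: the limit of > 100000 nM in this assay, at which 2 of the 4 values shown sit.

The compounds shown do not separate the contribution of the ring from that of its methyl, so plain phenyl would be the direct test of whether the methyl matters. Going by these compounds, it also remains open how this nitrogen responds to a phenyl ring carrying an amine or a carboxylic acid, or to benzyl, which sets a single carbon between the ring and the nitrogen.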